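The source may report more compounds than this note shows. Statements on the series, on what has been measured and on what is new or still open speak of the compounds shown alone.

Compound 1 `C=C1C(=O)O[C@@H](C2CCCCC2)[C@H]1c1ccccc1`: 81%
Compound 2 `C=C1C(=O)O[C@@H](c2ccccc2)[C@H]1c1ccccc1`: 3%
Compound 3 `C=C1C(=O)O[C@H](c2ccccc2)[C@H]1c1ccccc1`: 1%

In a functional assay on MIA PaCa-2 cells (Homo sapiens) for cytotoxicity, read by MTT assay, with a stated time of 72 h, tested at 10 uM (a higher number here means a weaker effect of the compound at the concentration tested, a lower number a stronger effect), compound 3 gives 1%, the lowest of the three numbers; the step of a number 2 percentage points lower from compound 2 to compound 3 (within the scatter) lies within the scatter, which fits the fact that (the fact that compounds 2 and 3 differ only in the configuration as drawn). Compound 1, by contrast, stands far higher, the step of a number 78 percentage points lower from compound 1 to compound 2 (beyond the scatter) being large. Compound 4 `C=C1C(=O)O[C@H](c2ccc(OC)cc2)[C@H]1c1ccccc1` differs from compound 3 in one place: methoxy in place of hydrogen on an aromatic carbon. Neither measured step touches the aromatic ring, so neither bears directly on this change; the large step concerned the saturated ring carbon, the small one only configuration. Since compound 3 already sits near the bottom of the scale, little room remains downward, and the step of a number 3 percentage points higher from compound 3 to compound 4 (within the scatter) is expected to stay within the scatter. Compound 4 is therefore estimated at 4%, ranging from 0% to 25%.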

Compound 4, a percentage reported as activity, at one concentration (the size of the read-out at that concentration, not a potency): 0%
The estimate for compound 4 lay 4 percentage points above the measured number; the range from low to high includes it.
By their numbers in this assay, from the lowest: compounds 4, 3 and 2 (each within the scatter of the next); then compound 1.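

In this assay, going by these compounds alone, methoxy in place of hydrogen gives a number 1 percentage points lower from compound 3 to compound 4 (within the scatter), so this aromatic carbon, para to a large group and untouched by the earlier steps, accepts methoxy with the strong effect kept. Both compounds sit so near the bottom of the scale that any further gain could hardly show at this single concentration. Nothing known here bears on this change. On these data alone, whether an amine or a carboxylic acid at this carbon would keep the effect stays open, as does how these compounds would compare at lower concentrations.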